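Toward compound 4: replacing the pyridyl arm of compound 3

The source may hold more compounds than are shown below. What is called first, only, known or untested is meant among the compounds shown, and "the series" means these compounds.

Values in an assay for inhibition of inositol hexakisphosphate kinase 2 (Homo sapiens), read by colorimetric assay, coupled enzyme assay and malachite green, with a stated time of 120 min, in the presence of a further agent that is not named here (a higher number here means a weaker inhibitor, a lower number a stronger inhibitor), for the three measured compounds:

compound 1 `CN(C)C(=O)/C=C/c1ccc2noc(-c3ccccc3)c2c1`: 40300 nM
compound 2 `CNC(=O)/C=C/c1ccc2noc(-c3ccccc3)c2c1`: 58200 nM
compound 3 `O=C(O)c1ccc2noc(-c3ccc(-c4ccncc4)cc3)c2c1`: 150 nM

Compound 3 stands lowest of the three, far apart from compound 1 and compound 2, both of which sit beyond the scatter above it. Within the data shown here, the only step between measured neighbours, a 1.4-fold higher number from compound 1 to compound 2 (0.16 log units; within the scatter), concerns the amide end of those two compounds and lies within the scatter; it does not touch the part of the structure that changes next.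

Compound 4 `O=C(O)c1ccc2noc(-c3ccc(N4CCCC4=O)cc3)c2c1` differs from compound 3 by 2-oxopyrrolidin-1-yl in place of pyridin-4-yl on an aromatic carbon. No measured pair shows an exchange of this kind, and no measured step bears on it, so the size and direction of the step cannot be read from the data shown. The shared core and the rest of compound 3 are retained in compound 4.

Compound 4 is therefore expected to fall near 400 nM in this assay, with a wide range from 100 nM to 2000 nM. The expected step of a 2.7-fold higher number from compound 3 to compound 4 (0.43 log units; beyond the scatter) is placed on the weaker side, but uncertainty spans both directions.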

Compound 4, half-maximal inhibitory concentration: 480 nM
Compound 4: the middle estimate sits 1.2-fold (0.08 log units) below what was measured, within the range that was stated.
By their numbers in this assay, from the lowest: compound 3; then compound 4; then compounds 1 and 2 (each within the scatter of the next).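

In this assay, 2-oxopyrrolidin-1-yl in place of pyridin-4-yl, on an aromatic carbon para to a large group, gives a 3.2-fold higher number from compound 3 to compound 4 (0.51 log units; beyond the scatter). Among these compounds, this is the first reading at this position, and it shows that the six-membered aromatic ring of pyridin-4-yl can be exchanged for a five-membered non-aromatic ring at a modest cost, with compound 4 still at 480 nM. No measurement shown accounts for the direction or size of this step.

This single exchange alters ring size, aromaticity and the hetero atoms together, so the contribution of each cannot be separated: piperidin-2-one, pyrrolidin-1-yl and pyridin-3-yl at the same carbon would begin to pull these changes apart. Also open, from the compounds shown here alone, is how the remaining end of the series responds when a group such as tetrazole takes the place of the carboxylic acid while pyridin-4-yl or 2-oxopyrrolidin-1-yl stays in place.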